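The compounds below may be only part of what the source reports. "The series", "measured", "known", "first", "only" and "open" are said of these compounds alone.

In a functional assay on HCT-116 cells (Homo sapiens) for inhibition, read by MTT assay, with a stated time of 72 h (on this read-out higher numbers stand for weaker inhibition and lower numbers for stronger inhibition), compound 3 (`Nc1nc2cc(-c3nn(CCCCCCCCC(=O)NO)c4ncnc(N)c34)ccc2o1`) gives 2980 nM and holds the lowest number of the three measured compounds. Compound 1 (`Nc1nc2cc(-c3nn(CCCC(=O)NO)c4ncnc(N)c34)ccc2o1`) gives 19600 nM on the same read-out. Compound 2 (`Nc1nc2cc(-c3nn(CCCCCCCCCC(=O)NO)c4ncnc(N)c34)ccc2o1`) gives 23100 nM there, and the step between these two (a 1.2-fold higher number from compound 1 to compound 2 (0.07 log units; within the scatter)) lies within the scatter. Going by the values given here, compound 4 (`CNC(=O)CCCCCCCn1nc(-c2ccc3oc(N)nc3c2)c2c(N)ncnc21`) has no measurement yet. It carries methylcarbamoyl in place of (hydroxycarbamoyl)methyl on a saturated chain carbon, seven bonds along the chain from an aromatic nitrogen. Among the compounds with values here, all three measured compounds end in hydroxycarbamoyl, so no measured step shows directly what replacing that group does. The closest guides are the two chain changes that lead to compound 3 (a 6.6-fold lower number from compound 1 to compound 3 (0.82 log units; beyond the scatter)) and (a 7.8-fold lower number from compound 2 to compound 3 (0.89 log units; beyond the scatter)). Both are modest but beyond the scatter, and they show that, among these three compounds, leaving compound 3 has meant a higher number. A step of similar size toward a higher number is therefore expected in this assay for this larger change. The estimate amounts to a 6.0-fold higher number from compound 3 to compound 4 (0.78 log units; beyond the scatter) as the expected step. Compound 4 is estimated at 18000 nM with 6000 nM to 60000 nM as the expected range.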

Compound 4, half-maximal inhibitory concentration: 3150 nM
Compound 4: the middle estimate sits 5.7-fold (0.76 log units) above what was measured; the whole stated range lies above it.
By their numbers in this assay, from the lowest: compounds 3 and 4 (each within the scatter of the next); then compounds 1 and 2 (each within the scatter of the next).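

In this assay, the numbers for methylcarbamoyl and (hydroxycarbamoyl)methyl at this place, on a saturated chain carbon seven bonds along the chain from an aromatic nitrogen, cannot be told apart (a 1.1-fold higher number from compound 3 to compound 4 (0.02 log units; within the scatter)). Going by these compounds alone, all the earlier compounds ended in hydroxycarbamoyl and differed only in their chains, so they could not show that a chain without this ending can still give a number level with that of compound 3. Compound 4 also stands clear of the other two compounds, as the steps beyond the scatter show (a 7.3-fold lower number from compound 2 to compound 4 (0.87 log units; beyond the scatter); a 6.2-fold lower number from compound 1 to compound 4 (0.79 log units; beyond the scatter)), and no measurement shown accounts for how closely the two different chain ends agree.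

As far as these compounds go, whether a carboxylic acid or an amine in the same place would also give a number level with these two stays open. Also open, from the compounds shown here alone, is whether methylcarbamoyl on a shorter or a longer chain would move away from compound 4 in the way that the hydroxycarbamoyl compounds 1 and 2 stand apart from compound 3.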